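The source may hold more compounds than are shown below. What is called first, only, known or untested is meant among the compounds shown, and "the series" means these compounds.

Among the compounds with values here, in a functional assay on the whole organism for antagonist activity, with Mus musculus as the target (on this read-out higher numbers stand for an effect only at larger amounts of compound and lower numbers for an effect already at smaller amounts), compound 1 (`CC(=O)N(C)C(C)C#CCn1cncc1C`) gives 3.7 mg/kg, the only true number measured so far. Compound 2 (`CC(=O)N(C)CC#CCn1ccnc1`) gives > 100 mg/kg. That entry is a limit of the assay and not a number, so compound 2 has no exact position on the scale. Compound 1 and compound 2 differ in more than one place, so the gap between them cannot be assigned to any single change.

The next compound, compound 3 (`CC(=O)N(C)CC#CCn1cncc1C`), departs from compound 2 in one place only: methyl in place of hydrogen on an aromatic carbon. In words, this is methyl in place of hydrogen on an aromatic carbon. Within the data shown here, no single-change step has been measured in this assay, so any forecast is rough. The expectation rests on compound 1 at 3.7 mg/kg, which shows that a numerical reading is attainable among these compounds. A move towards smaller doses, beyond the usual scatter, is therefore expected, and the estimated step is an at least 3.3-fold lower number from compound 2 to compound 3 (0.52 log units; beyond the scatter). A second limit reading remains a real possibility. For compound 3 the expected value is 30 mg/kg, with an estimated range from 8 mg/kg to 100 mg/kg.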

Compound 3, dose for half-maximal effect: > 100 mg/kg
Compound 3 ended at the assay's limit (the forecaster's own chance of this, stated with the estimate: 35%); middle value at least 3.3-fold (0.52 log units) from the limit.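

The methyl on an aromatic carbon of the five-membered aromatic ring does not by itself bring a numerical reading in this assay: compound 3 carries it and gives > 100 mg/kg, which is a limit of the assay and not a number. The step for this change cannot be read, because both of its ends sit at a limit: the limit of > 100 mg/kg in this assay, at which 2 of the 3 values shown sit.

The one step that can be read points to the other place of difference, where hydrogen in place of methyl on a saturated chain carbon bound to an amide-type nitrogen and a triple-bonded carbon comes with an at least 27-fold higher number from compound 1 to compound 3 (1.43 log units; beyond the scatter), so this chain methyl, and not the ring methyl alone, marks the numerical reading among the compounds shown.

Going by these compounds, what the ring methyl contributes when the chain methyl is present remains open. On these data alone, it is also open whether an ethyl group or a longer chain on that saturated carbon would keep a numerical reading in this assay.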